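This account rests on a few compounds, and the source may have more. Where it says the series, first, only, none or still open, it means among the compounds named here.

Measured compounds:
compound 1 `CCN(C/C=C/C#CC(C)(C)C)Cc1cccc(OC[Si](C)(C)c2ccc(F)cc2)c1` in a functional assay on liver (Sus scrofa) for inhibition of squalene monooxygenase (Homo sapiens), using microsomes (a lower number here means a stronger inhibitor, a higher number a weaker inhibitor), gives 60 nM
compound 2 `CCN(C/C=C/C#CC(C)(C)C)Cc1cccc(OC[Si](C)(C)c2cccc(C)c2)c1` in this assay gives 3000 nM

Among the compounds with values here, compound 1 gives the lowest number of the two; the only other measured compound is compound 2, with a 50-fold higher number from compound 1 to compound 2 (1.70 log units; beyond the scatter) when 3-methylphenyl replaces 4-fluorophenyl on the silicon.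

Compound 3 `CCN(C/C=C/C#CC(C)(C)C)Cc1cccc(OC[Si](C)(C)c2ccccc2C(F)(F)F)c1` is not yet measured. It differs from compound 1 as follows: 2-(trifluoromethyl)phenyl in place of 4-fluorophenyl on a silicon

Within the data shown here, only one measured step bears on this, the change of the ring on the silicon from compound 1 to compound 2, and it was large: a 50-fold higher number from compound 1 to compound 2 (1.70 log units; beyond the scatter). Among the measured compounds shown here, the group entering in compound 3 is 2-(trifluoromethyl)phenyl rather than 3-methylphenyl, so the step is not the same one; the single step available shows, however, that moving away from 4-fluorophenyl on this silicon can cost much in this assay. A weakening beyond the scatter is therefore expected for compound 3, though smaller than the step to compound 2 is judged plausible, because a 50-fold higher number from compound 1 to compound 2 (1.70 log units; beyond the scatter) concerns a different ring. The expected step is a 10-fold higher number from compound 1 to compound 3 (1.00 log units; beyond the scatter). Compound 3 is estimated at 600 nM, with a range from 100 nM to 4000 nM.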

Compound 3, half-maximal inhibitory concentration: 70 nM
For compound 3 the middle estimate is 8.6-fold (0.93 log units) above the measured one; the measured number lies below the stated range.
By their numbers in this assay, from the lowest: compounds 1 and 3 (each within the scatter of the next); then compound 2.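

In this assay, the ring on the silicon proves less demanding than the earlier pair suggested: a 1.2-fold higher number from compound 1 to compound 3 (0.07 log units; within the scatter), so leaving 4-fluorophenyl does not by itself raise the number, even with 2-(trifluoromethyl)phenyl as the larger entering group by heavy-atom count. Set against the other ring, a 43-fold lower number from compound 2 to compound 3 (1.63 log units; beyond the scatter), which places the high number among these three compounds with 3-methylphenyl alone and shows that two different substituted phenyl rings on this silicon can give numbers within the scatter of each other. No measurement at hand accounts for this difference between the rings, so the result stands as an observation without an explanation.

As far as these compounds go, compound 2 differs from compound 3 in both the substituent and its place on the ring, so it remains open whether the high number follows the methyl group, its place, or the two together; 2-methylphenyl and 3-(trifluoromethyl)phenyl on the silicon would separate these. Also open, from the compounds shown here alone, is how unsubstituted phenyl, or a ring carrying an amine or a carboxylic acid, would behave at this position.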